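Butyl addition on two cores: expected outcome for compound 4

This account rests on a few compounds, and the source may have more. Where it says the series, first, only, none or still open, it means among the compounds named here.

Measured so far in a functional assay for inhibition, with Rattus norvegicus as the target; on this read-out lower numbers stand for stronger inhibition and higher numbers for weaker inhibition:
compound 1, `CCCCc1cc(OC)c2ccccc2c1OC(C)=O`: 440 nM
compound 2, `CCCCc1ccc2c(OC(C)=O)c(CCCC)cc(OC)c2c1`: 480 nM
compound 3, `CCCCc1cc(OC)c2occc2c1O`: 11900 nM

Compound 3 sits with the highest number of the three; against compound 2 its number is higher by a margin beyond the scatter, and against compound 1 likewise. How the core of compound 3 differs from the core of compound 1 is not broken down here.

Compound 1 and compound 2 share a core and differ by butyl in place of hydrogen on an aromatic carbon. That step, a 1.1-fold higher number from compound 1 to compound 2 (0.04 log units; within the scatter), lies within the scatter.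

The unmeasured compound 4, `CCCCc1c(CCCC)c(OC)c2occc2c1O`, differs from compound 3 by butyl in place of hydrogen on an aromatic carbon. The group enters on an aromatic carbon of the same kind as before, but here the place is ortho to a butyl group, ortho to a methoxy group, meta to a hydroxy group, meta to a fused ring and para to a fused ring, so this is the same kind of change, not the same one. Because a 1.1-fold higher number from compound 1 to compound 2 (0.04 log units; within the scatter) was within the scatter, the step to compound 4 is expected to be small as well, a 1.0-fold higher number from compound 3 to compound 4 (0.00 log units; within the scatter), in this assay. Among the measured compounds shown here, compound 4 is therefore estimated at 12000 nM, with a range from 5000 nM to 30000 nM; only two compounds support the step and its surroundings differ, so the range is kept wide.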

Compound 4, half-maximal inhibitory concentration: 1150 nM
For compound 4 the middle estimate is 10-fold (1.02 log units) above the measured one; measured number outside the range, below it.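

In this assay, butyl in place of hydrogen on an aromatic carbon gives a 10-fold lower number from compound 3 to compound 4 (1.01 log units; beyond the scatter), a large step on the core of compound 3. The change therefore does not carry over with one size between these cores, and its size on the core of compound 1 gives no safe reading for the core of compound 3: the same change on two cores in this assay, a 1.1-fold higher number (0.04 log units; within the scatter) from compound 1 to compound 2 and a 10-fold lower number (1.01 log units; beyond the scatter) from compound 3 to compound 4, 11-fold (1.05 log units) apart, beyond the scatter of two such steps. Among the compounds shown here, this rests on only two pairs, and in compound 4 the butyl group enters ortho to a butyl group and ortho to a methoxy group, so the data do not separate a difference of core from a difference of place, nor do they show how the change behaves on any further core.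

Open, from the compounds shown here alone, is whether a shorter or longer chain, such as ethyl or hexyl, would follow butyl at this place on the core of compound 3, or whether an amine or a carboxylic acid there would give a step of similar size. Also open, going by these compounds, is how compound 4 would read with an acetyl ester in place of its hydroxy group.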